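The source may hold more compounds than are shown below. What is called first, only, known or untested is meant among the compounds shown, and "the series" means these compounds.

Compound 1 `O=c1ccn(CCCCCOc2ccc([N+](=O)[O-])cc2)c(=O)[nH]1` carries a nitro on an aromatic carbon of a six-membered aromatic ring of carbon only, para to a large group. In an ADME assay on HEL cells (Homo sapiens) for cytotoxicity (on this read-out higher numbers stand for lower toxicity in this test and lower numbers for higher toxicity in this test), compound 1 gives "not determined" (no result reported), so no single number places it. Two further compounds belong to the same set. Compound 3 `O=c1ccn(CCCOc2ccc(Br)cc2)c(=O)[nH]1` gives in this assay "not determined" (no result reported), again no number. Compound 2 `Cc1cn(CCCCCOc2ccc(Br)cc2)c(=O)[nH]c1=O` gives in this assay > 100000 nM, which is a limit of the assay and not a number. Compound 2 thus sits at the limit of > 100000 nM in this assay, at which 1 of the 3 values shown sits. Compound 1 therefore stands among entries of which one is a limit and two carry no result at all.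

Compound 4 `N#Cc1ccc(OCCCCCn2ccc(=O)[nH]c2=O)cc1` differs from compound 1 in one place: cyano in place of nitro on an aromatic carbon. Among the compounds with values here, no step between measured compounds of this kind exists here, and compound 1 itself has no number, so the account expects no shift in this assay beyond the usual scatter, in neither direction. Compound 4 is estimated at 100000 nM, within a range from 30000 nM to 300000 nM, with a fair chance that only a limit is reported.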

Compound 4, half-maximal cytotoxic concentration: 100000 nM
Compound 4: the middle estimate sits on the measured number at the digits printed; low and high end bracket the measured number.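

Within the data shown here, compound 1 has no number in this assay, so no step from it to compound 4, at 100000 nM, can be read. Compound 2 gives only a limit and not a number: the limit of > 100000 nM in this assay, at which 1 of the 4 values shown sits.

The compounds shown leave open whether cyano in place of nitro changes this read-out at all.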